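Half-life notes: pentafluoroethyl analogue of compound 1

This account rests on a few compounds, and the source may have more. Where it says the series, first, only, none or still open, it means among the compounds named here.

Measured compounds in an ADME assay on microsomes from liver (Rattus norvegicus, strain Sprague-Dawley) for metabolic stability, read by HPLC, using NADPH, with stated times of 5 min and 60 min, tested at 10 uM; on this read-out lower numbers stand for a shorter-lived compound and higher numbers for a longer-lived compound:
compound 1 `CS(=O)(=O)Nc1ccc(CNC(=O)c2ccc(C3(C(F)(F)F)CC3)cc2)c(Cl)c1` gives 3.03 h
compound 2 `CC(C)Oc1ccc(C(=O)NCc2ccc(NS(C)(=O)=O)cc2Cl)cc1` gives 1.85 h
compound 3 `COC(C)(C)c1ccc(C(=O)NCc2ccc(NS(C)(=O)=O)cc2Cl)cc1` gives 0.917 h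

Compound 1 stands highest of the three numbers in this assay. Its nearest neighbour is compound 2, with a 1.6-fold lower number from compound 1 to compound 2 (0.21 log units; within the scatter); the furthest is compound 3, with a 3.3-fold lower number from compound 1 to compound 3 (0.52 log units; beyond the scatter). Between the two lower compounds the step is a 2.0-fold lower number from compound 2 to compound 3 (0.30 log units; within the scatter).

Compound 4 `CS(=O)(=O)Nc1ccc(CNC(=O)c2ccc(C(F)(F)C(F)(F)F)cc2)c(Cl)c1` differs from compound 1 in one place: 1,1,2,2,2-pentafluoroethyl in place of 1-(trifluoromethyl)cyclopropyl on an aromatic carbon.

Neither measured step bears directly on this change: both steps from compound 1 replace the 1-(trifluoromethyl)cyclopropyl group with an oxygen-bearing group, and both lower the number, one within the scatter and one beyond it. For the measured compounds named here, no measured step swaps one fluorinated carbon group for another. Compound 4 keeps a fully fluorinated carbon group on the same aromatic carbon, so the expected step in this assay is a 1.2-fold higher number from compound 1 to compound 4 (0.06 log units; within the scatter), a change not expected to exceed the scatter in either direction. Compound 4 is therefore estimated at 3.5 h, with a range of 1.8 h to 7 h.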

Compound 4, half-life: 1.6 h
Estimate against measurement, compound 4: 2.2-fold (0.34 log units) above; measured number outside the range, below it.
By their numbers in this assay, from the lowest: compounds 3, 4, 2 and 1 (each within the scatter of the next, the first and the last beyond it).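

In this assay the swap of one fluorinated carbon group for another on this aromatic carbon, 1,1,2,2,2-pentafluoroethyl in place of 1-(trifluoromethyl)cyclopropyl, gives a 1.9-fold lower number from compound 1 to compound 4 (0.28 log units; within the scatter) and does not separate the two compounds. Compound 4 is not separated from the oxygen-bearing groups either, with a 1.2-fold lower number from compound 2 to compound 4 (0.06 log units; within the scatter) against isopropoxy and a 1.7-fold higher number from compound 3 to compound 4 (0.24 log units; within the scatter) against 1-methoxy-1-methylethyl, so a fluorinated group without a ring does not stand apart from them here, although compound 1 and compound 3 do stand apart from each other. Nothing measured on these compounds accounts for the number of compound 4.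

Open, on these data alone, is whether a lone trifluoromethyl group, a longer perfluoroalkyl chain or a nitrile on the same aromatic carbon would keep the number of compound 1. Also open is how an amine or a carboxylic acid there would read in this assay against the compounds shown.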